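A methyl shift on the aryl sulfone of compound 1

A few compounds are considered here, and "the series" means these few. Any claim that something is new, unique, unknown or untested is made for them only; others in the source may bear on it.

In an ADME assay on microsomes from liver (Homo sapiens) for metabolic stability, read by LC-MS, with a stated time of 30 min, tested at 1 uM (on this read-out lower numbers stand for a less stable compound and higher numbers for a more stable compound), compound 1 (`Cc1ccccc1S(=O)(=O)c1ccc(CNC(=O)c2cc3cnccc3[nH]2)cc1`) gives 48% and lies within the scatter of compound 3 (`O=C(NCc1ccc(S(=O)(=O)N2CCCCC2)cc1)c1ccn2cncc2c1`) at 54% while compound 2 (`O=C(NCc1ccc(S(=O)(=O)c2ccccc2)cc1)c1nc2cnccc2[nH]1`) stands at 73% on this read-out. The gap between compound 1 and compound 2 lies beyond the scatter, with compound 2 the higher of the two. Compound 4 (`Cc1cccc(S(=O)(=O)c2ccc(CNC(=O)c3cc4cnccc4[nH]3)cc2)c1`) differs from compound 1 in one place, with 3-methylphenyl in place of 2-methylphenyl on a sulfonyl sulfur and the same atoms joined differently. Going by the values given here, no measured pair isolates such a change, so the expectation starts from compound 1 at 48% and no step beyond the scatter is expected in this assay in either direction. The estimated step is small (a number 1 percentage points lower from compound 1 to compound 4 (within the scatter)) on this reasoning. Compound 4 is expected at 47% with 30% and 65% as the estimated ends of its range.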

Compound 4, percent of the compound remaining: 49%
Beside the measured number, compound 4's estimate is 2 percentage points below it; the measured number falls inside the stated range.
By their numbers in this assay, from the lowest: compounds 1, 4 and 3 (each within the scatter of the next); then compound 2.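

In this assay, 3-methylphenyl in place of 2-methylphenyl on a sulfonyl sulfur gives a number 1 percentage points higher from compound 1 to compound 4 (within the scatter) on the shared core. Going by these compounds alone, this is the first pair here that differs in one place, and it shows that, at this position, the two methylphenyl groups cannot be told apart on this read-out. Nothing available here bears on why this is so. Going by these compounds, whether a methoxy group, a chlorine or an amine on this aryl ring would leave the read-out equally unchanged remains open.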